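Adding a Third Hydroxy Group to Compound 2

A few compounds are considered here, and "the series" means these few. Any claim that something is new, unique, unknown or untested is made for them only; others in the source may bear on it.

Measured so far:
compound 1 `Cc1c(C(=O)N/N=C\c2c(O)cccc2F)oc2cccc(O)c12`: 8230 nM
compound 2 `Cc1c(C(=O)N/N=C\c2ccc(O)cc2O)oc2cccc(O)c12`: 9770 nM

Within the data shown here, in a functional assay on PANC-1 cells (Homo sapiens) for inhibition (on this read-out lower numbers stand for stronger inhibition and higher numbers for weaker inhibition), compound 2 sits at the top of these two numbers, but that position means little, since the only measured step, a 1.2-fold higher number from compound 1 to compound 2 (0.07 log units; within the scatter), stayed within the scatter. Compound 3 `Cc1c(C(=O)N/N=C\c2ccc(O)c(O)c2O)oc2cccc(O)c12` differs from compound 2 by hydroxy in place of hydrogen on an aromatic carbon. Among the measured compounds shown here, the one known step swapped whole substitution patterns on that ring without a shift beyond the scatter, and no step adds a single hydroxy, so no change beyond the scatter is expected in this assay. Compound 3 is expected near 9000 nM, between 3500 nM and 25000 nM. That expected step is a 1.1-fold lower number from compound 2 to compound 3 (0.04 log units; within the scatter).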

Compound 3, half-maximal inhibitory concentration: > 20000 nM
Compound 3 gave a limit, no number; the forecaster's own chance of this, stated with the estimate: 10%; middle value at least 2.2-fold (0.34 log units) away from the limit.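

On this ring, the position ortho to two hydroxy groups turns out to matter: a single added hydroxy group in this assay gives an at least 2.0-fold higher number from compound 2 to compound 3 (0.31 log units; beyond the scatter), while the earlier swap of whole substitution patterns stayed within the scatter. So a small change can weaken inhibition more than a larger rearrangement did. The reading for compound 3 is a limit, not a number: the limit of > 20000 nM in this assay, at which 1 of the 3 values shown sits.

As far as these compounds go, how much weaker compound 3 truly is stays open. Also open, from the compounds shown here alone, is whether a methoxy group or an amine on this same aromatic carbon would shift the number as well.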